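Methyl on a piperidine carbon across two amide cores

This account rests on a few compounds, and the source may have more. Where it says the series, first, only, none or still open, it means among the compounds named here.

Measured, all in a functional assay on HT-29 cells (Homo sapiens) for cytotoxicity, read by MTT assay, with a stated time of 72 h; a higher number here means a weaker inhibitor, a lower number a stronger inhibitor:
compound 1, `COc1cc2c(Oc3ccc(NC(=O)c4nnn(-c5ccccc5)c4C)cc3F)ccnc2cc1OCCCN1CCCCC1`: 120 nM
compound 2, `COc1cc2c(Oc3ccc(NC(=O)c4nnn(-c5ccc(F)cc5)c4C(F)(F)F)cc3F)ccnc2cc1OCCCN1CCCCC1`: 150 nM
compound 3, `COc1cc2c(Oc3ccc(NC(=O)c4nnn(-c5ccccc5)c4C)cc3F)ccnc2cc1OCCCN1CCC(C)CC1`: 140 nM

Compound 3 differs from compound 1 by methyl in place of hydrogen on a saturated ring carbon; that step is a 1.2-fold higher number from compound 1 to compound 3 (0.07 log units; within the scatter). Compound 2 and compound 1 carry different cores, and the difference between the two cores is not broken down here; their values in this assay lie within the scatter of each other.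

Compound 4, `COc1cc2c(Oc3ccc(NC(=O)c4nnn(-c5ccc(F)cc5)c4C(F)(F)F)cc3F)ccnc2cc1OCCCN1CCC(C)CC1`, is not yet measured. It stands to compound 2 as compound 3 stands to compound 1: methyl in place of hydrogen on a saturated ring carbon, the same kind of change at the same place. For compound 4 the expected step is a 1.1-fold higher number from compound 2 to compound 4 (0.05 log units; within the scatter), because the same change gave a 1.2-fold higher number from compound 1 to compound 3 (0.07 log units; within the scatter) on the core of compound 1. Compound 4 is therefore estimated at 170 nM in this assay, between 90 nM and 330 nM.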

Compound 4, half-maximal inhibitory concentration: 160 nM
Compound 4: middle estimate off by 1.1-fold (0.03 log units), on the high side; the measured number falls inside the stated range.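

In this assay going from piperidin-1-yl to 4-methylpiperidin-1-yl gives a 1.1-fold higher number from compound 2 to compound 4 (0.03 log units; within the scatter), and the change reads alike on both cores: the same change on two cores in this assay, a 1.2-fold higher number (0.07 log units; within the scatter) from compound 1 to compound 3 and a 1.1-fold higher number (0.03 log units; within the scatter) from compound 2 to compound 4, 1.1-fold (0.04 log units) apart, within the scatter of two such steps. This shows that the change carries from one core to the other in the narrow sense that neither step moves the number beyond the scatter. It does not show how the two cores would compare with a change that has a measurable effect, and two pairs set no rule for the series.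

Open, going by these compounds, is whether a hydroxyl or a carboxylic acid at the same ring carbon would behave alike on both cores. Also open, on these data alone, is what a morpholine in place of the piperidine would give on either core.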